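A few compounds are considered here, and "the series" means these few. Any claim that something is new, unique, unknown or untested is made for them only; others in the source may bear on it.

Compound 1, `CCC1=C(O)c2c(oc(-c3ccc(O)cc3)cc2=O)C(CC)(CC)C1=O`, in a functional assay on KBVIN cells (Homo sapiens) for antiproliferative activity, read by sulforhodamine B assay, with a stated time of 3 days (on this read-out higher numbers stand for an effect only at larger amounts of compound and lower numbers for an effect already at smaller amounts), gives 20.6 uM, the highest number among the three measured compounds. Compound 2, `CCC1=C(O)c2c(oc(-c3ccc(OC)cc3)cc2=O)C(CC)(CC)C1=O`, gives 0.68 uM, and compound 3, `CCC1=C(O)c2c(oc(-c3cccc(C(F)(F)F)c3)cc2=O)C(CC)(CC)C1=O`, gives 5.42 uM. Among the compounds with values here, the one single-point step recorded is a 30-fold lower number from compound 1 to compound 2 (1.48 log units; beyond the scatter), a large drop that places compound 2 well below compound 1. Within the data shown here, compound 3 also sits below compound 1 by a margin that the numbers show to be beyond the usual scatter, although no single-point step joins those two.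

Compound 4, `CCC1=C(O)c2c(oc(-c3ccc(C)cc3C)cc2=O)C(CC)(CC)C1=O`, is not yet measured. It differs from compound 1 by 2,4-dimethylphenyl in place of 4-hydroxyphenyl on an aromatic carbon. The free hydroxyl of compound 1 is gone, as it is in compound 2, but here two methyl groups are carried on the ring instead of an ether. The step that bears on this is a 30-fold lower number from compound 1 to compound 2 (1.48 log units; beyond the scatter), which shows that losing the free hydroxyl coincided with a large gain. Compound 4 is therefore expected to show a clearly lower number than compound 1, an 8.2-fold lower number from compound 1 to compound 4 (0.92 log units; beyond the scatter), though a smaller gain than compound 2 is assumed since the change is not the same. Compound 4 is estimated at 2.5 uM, with a range from 0.6 uM to 10 uM.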

Compound 4, concentration for half-maximal effect: 8.52 uM
For compound 4 the middle estimate is 3.4-fold (0.53 log units) below the measured one, within the range that was stated.
By their numbers in this assay, from the lowest: compound 2; then compounds 3 and 4 (each within the scatter of the next); then compound 1.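

In this assay, the step to 2,4-dimethylphenyl is a 2.4-fold lower number from compound 1 to compound 4 (0.38 log units; beyond the scatter), so a ring without the free hydroxyl can read lower than compound 1 by much less than the 4-methoxyphenyl ring does. Set against that ring, the same group gives a 13-fold higher number from compound 2 to compound 4 (1.10 log units; beyond the scatter), which shows that at this aromatic carbon next to the ring oxygen, the loss of the hydroxyl does not settle the number on its own: what stands on the ring in its place matters a great deal. Nothing measured alongside these compounds accounts for the difference between the two rings.

As far as these compounds go, compound 4 carries its two methyl groups together, so it remains open whether either methyl alone would give a number nearer to that of compound 2 or to that of compound 1. From the compounds shown here alone, it also remains open how the ring would read with an amine or a longer ether chain, such as ethoxy, in place of the hydroxyl.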